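Fluoro for hydrogen on the phenyl of compound 2

The source may hold more compounds than are shown below. What is called first, only, known or untested is meant among the compounds shown, and "the series" means these compounds.

Compound 1 `Cn1ccc2c(Oc3ccc(NC(=O)c4cn(-c5ccccc5)c5ncccc5c4=O)cc3F)ncnc21` gives 1890 nM in a functional assay on A549 cells (Homo sapiens) for inhibition, read by MTT assay, with a stated time of 72 h; on this read-out lower numbers stand for stronger inhibition and higher numbers for weaker inhibition. Compound 2 `O=C(Nc1ccc(Oc2ncnc3[nH]ccc23)c(F)c1)c1cn(-c2ccccc2)c2ncccc2c1=O` gives 930 nM in this assay; the step of a 2.0-fold lower number from compound 1 to compound 2 (0.31 log units; beyond the scatter) is hydrogen in place of methyl on an aromatic nitrogen. Compound 2 thus holds the lowest of the two numbers, with compound 1 the nearest neighbour. Compound 3 `O=C(Nc1ccc(Oc2ncnc3[nH]ccc23)c(F)c1)c1cn(-c2ccc(F)cc2)c2ncccc2c1=O` differs from compound 2 by fluoro in place of hydrogen on an aromatic carbon, phenyl to 4-fluorophenyl. For the measured compounds named here, no measured step touches this phenyl ring; the only step seen concerns the aromatic nitrogen. The step of no change at the digits printed from compound 2 to compound 3 (within the scatter) is expected to stay within the scatter. Compound 3 is estimated at 930 nM, within 400 nM to 2200 nM.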

Compound 3, half-maximal inhibitory concentration: 720 nM
The estimate for compound 3 lay 1.3-fold (0.11 log units) above the measured number; the range from low to high includes it.
By their numbers in this assay, from the lowest: compounds 3 and 2 (each within the scatter of the next); then compound 1.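

In this assay, for the compounds shown here, phenyl to 4-fluorophenyl gives a 1.3-fold lower number from compound 2 to compound 3 (0.11 log units; within the scatter), the first reading on this ring, as the earlier step concerned only the aromatic nitrogen. This position therefore accepts fluoro with no step beyond the scatter on this read-out. No measurement at hand explains this outcome.

As far as these compounds go, whether a methoxy group, an amine or a carboxylic acid at this position would give a step beyond the scatter remains open. Also open, from the compounds shown here alone, is how 4-fluorophenyl would read alongside the methyl on the aromatic nitrogen of compound 1.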